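Sigma-2 series: pyridin-4-yl for cyclohexyl on the piperazine

The source may report more compounds than this note shows. Statements on the series, on what has been measured and on what is new or still open speak of the compounds shown alone.

Going by the values given here, compound 2 `Cc1cccc2sc(NC(=O)CCN3CCN(C4CCCCC4)CC3)nc12` gives 233 nM in an assay on membranes from liver for displacement of a labelled ligand from Sigma intracellular receptor 2 (Rattus norvegicus), read by scintillation counting, with a stated time of 120 min (on this read-out lower numbers stand for stronger inhibition and higher numbers for weaker inhibition), the higher of the two numbers so far; compound 1 `Cc1cccc2sc(NC(=O)CCN3CCN(C(C)(C)C)CC3)nc12` gives 200 nM in this assay, and the step of a 1.2-fold higher number from compound 1 to compound 2 (0.07 log units; within the scatter) is within the scatter. Compound 3 `Cc1cccc2sc(NC(=O)CCN3CCN(c4ccncc4)CC3)nc12` has not been measured; it differs from compound 2 by pyridin-4-yl in place of cyclohexyl on an amine nitrogen in a ring. Among the compounds with values here, the only measured step, from compound 1 to compound 2, exchanges one saturated carbon group for another on the same ring nitrogen and was within the scatter, so it bears on the site but not on an aromatic, acceptor-bearing entrant; no step addresses such a change. The shared core and the three-carbon linker to the piperazine stay the same. For compound 3 an estimate of 400 nM in this assay is made, with a range of 120 nM to 1300 nM, meaning an expected step of a 1.7-fold higher number from compound 2 to compound 3 (0.23 log units; within the scatter) toward a somewhat weaker number, but with wide uncertainty.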

Compound 3, inhibition constant: 1700 nM
Compound 3: the middle estimate sits 4.3-fold (0.63 log units) below what was measured; measured number outside the range, above it.
By their numbers in this assay, from the lowest: compounds 1 and 2 (each within the scatter of the next); then compound 3.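

In this assay, this amine nitrogen in a ring does not treat all six-membered groups alike: pyridin-4-yl in place of cyclohexyl gives a 7.3-fold higher number from compound 2 to compound 3 (0.86 log units; beyond the scatter) and pyridin-4-yl in place of tert-butyl gives an 8.5-fold higher number from compound 1 to compound 3 (0.93 log units; beyond the scatter). Both steps are modest but beyond the scatter, unlike the step between the two saturated carbon groups, and cyclohexyl and pyridin-4-yl both have 6 heavy atoms, so the change in number comes without a change in that count. No available evidence bears on why the number rises.

As far as these compounds go, whether the step follows the aromatic ring or the ring nitrogen within it stays open; phenyl on the same piperazine nitrogen would separate the two. Also open, from the compounds shown here alone, is whether the location of that ring nitrogen matters, as a comparison with pyridin-2-yl would show.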